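This account rests on a few compounds, and the source may have more. Where it says the series, first, only, none or still open, it means among the compounds named here.

In an ADME assay on NIH3T3 cells (Mus musculus) for cytotoxicity, read by MTT assay, with a stated time of 24 h (on this read-out lower numbers stand for stronger inhibition and higher numbers for weaker inhibition), three compounds that share one core and differ only in the group on a carbon with a double bond to nitrogen have been measured. Compound 1 `O=C(CSc1nnc(-c2ccncc2)o1)N/N=C/c1ccc(Cl)cc1` gives 181000 nM. Compound 2 `COc1cccc(/C=N/NC(=O)CSc2nnc(-c3ccncc3)o2)c1` gives 179000 nM, and compound 3 `O=C(CSc1nnc(-c2ccncc2)o1)N/N=C/c1ccccc1F` gives 142000 nM. The number for compound 3 is the smallest of the three, yet the other two lie close to it: the step of a 1.3-fold lower number from compound 1 to compound 3 (0.11 log units; within the scatter) and the step of a 1.3-fold lower number from compound 2 to compound 3 (0.10 log units; within the scatter) are both within the scatter, as is the step of a 1.0-fold lower number from compound 1 to compound 2 (0.00 log units; within the scatter). Compound 4 `O=C(CSc1nnc(-c2ccncc2)o1)N/N=C/c1ccccc1O` differs from compound 3 by hydroxy in place of fluoro on an aromatic carbon. The three measured steps are the only ones that bear on this change, and all of them, whichever group was exchanged on that carbon, stayed within the scatter. For the measured compounds named here, none of them involves hydroxy in place of fluoro, so no direct precedent exists. The expectation for compound 4 in this assay is therefore a step of no more than the scatter, a 1.0-fold higher number from compound 3 to compound 4 (0.01 log units; within the scatter), with no direction favoured. Compound 4 is estimated at 145000 nM, within a range from 70000 nM to 300000 nM.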

Compound 4, half-maximal inhibitory concentration: 155000 nM
The estimate for compound 4 lay 1.1-fold (0.03 log units) below the measured number; measured number inside the range.
By their numbers in this assay, from the lowest: compounds 3, 4, 2 and 1 (each within the scatter of the next).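

In this assay, the exchange on this aromatic carbon, ortho to a large group, now has a direct reading for hydroxy in place of fluoro (a 1.1-fold higher number from compound 3 to compound 4 (0.04 log units; within the scatter)), and it stays within the scatter even though hydroxy brings one hydrogen-bond donor and one hydrogen-bond acceptor where fluoro brings neither. The comparisons with the other two groups on the carbon with a double bond to nitrogen read the same way (a 1.2-fold lower number from compound 2 to compound 4 (0.06 log units; within the scatter); a 1.2-fold lower number from compound 1 to compound 4 (0.07 log units; within the scatter)), so the 2-hydroxyphenyl group joins the 2-fluorophenyl, 3-methoxyphenyl and 4-chlorophenyl groups in a set of four whose members all lie within the scatter of one another on the shared core. Nothing available gives a reason for this flat picture.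

The four compounds leave open whether an amine, a carboxylic acid or a longer alkoxy chain on this phenyl ring would produce a step beyond the scatter. They also leave open whether hydroxy in place of fluoro would stay within the scatter on a core other than this one.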